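Aryl variation on the saturated ring carbon of the shared core

A few compounds are considered here, and "the series" means these few. Any claim that something is new, unique, unknown or untested is made for them only; others in the source may bear on it.

Measured compounds:
compound 1 `COc1cccc(C2C(=O)N(C)c3cnc(Nc4ccc(S(N)(=O)=O)cc4)nc3N2C)c1`: 954 nM
compound 2 `CN1C(=O)C(c2ccccc2Cl)N(C)c2nc(Nc3ccc(S(N)(=O)=O)cc3)ncc21`: 129 nM

Going by the values given here, in an assay on Sf9 cells for inhibition of serine/threonine-protein kinase 4 (Homo sapiens), read by luminescence and ADP-Glo, with a stated time of 1 h, in the presence of a further agent that is not named here (a higher number here means a weaker inhibitor, a lower number a stronger inhibitor), compound 2 gives the lower of the two numbers, the only measured neighbour being compound 1 at 954 nM; the step of a 7.4-fold lower number from compound 1 to compound 2 (0.87 log units; beyond the scatter) is beyond the scatter, so compound 2 is the stronger of the pair in this assay.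

Compound 3 `CN1C(=O)C(c2c(F)cccc2F)N(C)c2nc(Nc3ccc(S(N)(=O)=O)cc3)ncc21` is not yet measured. Its change from compound 2: 2,6-difluorophenyl in place of 2-chlorophenyl on a saturated ring carbon. Among the compounds with values here, the one measured step, a 7.4-fold lower number from compound 1 to compound 2 (0.87 log units; beyond the scatter), is the only one that bears on the aryl group at this position, and it compared two different aryl groups rather than two substitution patterns on the same halogenated ring, so it gives only weak guidance. Compound 3 is expected to stay near compound 2, a step of a 1.0-fold higher number from compound 2 to compound 3 (0.00 log units; within the scatter) within the scatter. The estimate for compound 3 in this assay is 130 nM, range 40 nM to 420 nM.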

Compound 3, half-maximal inhibitory concentration: 42 nM
For compound 3 the middle estimate is 3.1-fold (0.49 log units) above the measured one; the measured number falls inside the stated range.
By their numbers in this assay, from the lowest: compound 3; then compound 2; then compound 1.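

In this assay, the aryl group on the saturated ring carbon still moves the number among halogenated rings: with a 3.1-fold lower number from compound 2 to compound 3 (0.49 log units; beyond the scatter) the change to 2,6-difluorophenyl from 2-chlorophenyl is not a neutral exchange. The span at this single position now reaches a 23-fold lower number from compound 1 to compound 3 (1.36 log units; beyond the scatter) in a large step, and both halogenated aryl groups give lower numbers than 3-methoxyphenyl. No measurement at hand explains the gain from the two fluorines.

On these data alone, whether the two fluorines themselves or the loss of chlorine carries the step stays open, as does the role of a second halogen on the ring in general. Also open, as far as these compounds go, is whether unsubstituted phenyl, a pyridine ring or a saturated cyclohexyl group at this carbon would hold the number.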